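A single halogen swap from compound 2 to compound 3

The source may report more compounds than this note shows. Statements on the series, on what has been measured and on what is new or still open speak of the compounds shown alone.

In an ADME assay on THP-1 cells (Homo sapiens) for cytotoxicity, read by flow cytometry and propidium iodide staining, with a stated time of 72 h (on this read-out lower numbers stand for stronger inhibition and higher numbers for weaker inhibition), compound 1 `Cc1nc(CS(=O)(=O)c2ccc(Br)cc2)c([N+](=O)[O-])n1CCO` gives 124000 nM as a measured number. Compound 2 `Cc1nc(CS(=O)(=O)c2ccc(Cl)cc2)c([N+](=O)[O-])n1CC(C)O` gives > 688000 nM as a limit of the assay and not a number. Compound 3 `Cc1nc(CS(=O)(=O)c2ccc(Br)cc2)c([N+](=O)[O-])n1CC(C)O` is still unmeasured, and it differs from compound 2 by bromo in place of chloro on an aromatic carbon in one place, bromo in place of chloro on an aromatic carbon. Within the data shown here, no measured pair shows this exchange, so with compound 1 at 124000 nM as the only number, a modest move toward stronger inhibition is expected in this assay here. The expected step of an at least 1.9-fold lower number from compound 2 to compound 3 (0.29 log units; that floor lies within the scatter) is only an estimate. Compound 3 is estimated at 350000 nM within an expected range of 120000 nM to 700000 nM as a rough guess.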

Compound 3, half-maximal inhibitory concentration: 126000 nM
The estimate for compound 3 lay 2.8-fold (0.44 log units) above the measured number, within the range that was stated.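

In this assay, 4-chlorophenyl giving way to 4-bromophenyl produces an at least 5.4-fold lower number from compound 2 to compound 3 (0.73 log units; beyond the scatter), so the halogen at this position counts for this read-out. Compound 2 carries a limit of the assay and not a number, so only the smallest possible size of this step is known: the limit of > 688000 nM in this assay, at which 1 of the 3 values shown sits. Methyl in place of hydrogen on the saturated chain carbon bound to an oxygen gives a 1.0-fold higher number from compound 1 to compound 3 (0.01 log units; within the scatter), so those two compounds read alike.

From the compounds shown here alone, what a fluoro, an iodo or a methoxy group would give at this position stays open, as does how the methyl behaves when chloro sits on the ring.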